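Hydroxy in place of methyl on the ester chain of compound 2

The source may hold more compounds than are shown below. What is called first, only, known or untested is meant among the compounds shown, and "the series" means these compounds.

In a functional assay on RAW264.7 cells (Mus musculus) for inhibition (on this read-out lower numbers stand for stronger inhibition and higher numbers for weaker inhibition), compound 1 (`CCOC(=O)C1=CCCCC1S(=O)(=O)Nc1ccccc1`) gives 260 nM and compound 2 (`CCCOC(=O)C1=CCCCC1S(=O)(=O)Nc1ccc(F)cc1F`) gives 29 nM as the lower of the two numbers, a gap beyond the usual scatter. These two compounds differ in more than one place, so their gap isolates no single change.

The change to compound 3 (`O=C(OCCO)C1=CCCCC1S(=O)(=O)Nc1ccc(F)cc1F`) is hydroxy in place of methyl on a saturated chain carbon, two bonds along the chain from an oxygen next to a carbonyl group on a saturated chain carbon, two bonds along the chain from an oxygen next to a carbonyl group, which reads as propyl to 2-hydroxyethyl. Going by the values given here, no measured pair shows this change, so there is no direct precedent for its size. Compound 2 at 29 nM holds the lower of the two numbers, and that leaves more room for a loss than for a gain. The expected outcome in this assay is a 2.8-fold higher number from compound 2 to compound 3 (0.44 log units; beyond the scatter) toward weaker inhibition, estimated as modest but beyond the scatter. The estimate for compound 3 is 80 nM with 20 nM and 320 nM as the expected ends of the range.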

Compound 3, half-maximal inhibitory concentration: 330 nM
Beside the measured number, compound 3's estimate is 4.1-fold (0.62 log units) below it, and the stated range ends below it.
By their numbers in this assay, from the lowest: compound 2; then compounds 1 and 3 (each within the scatter of the next).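

In this assay, going by these compounds alone, hydroxy in place of methyl on a saturated chain carbon, two bonds along the chain from an oxygen next to a carbonyl group gives an 11-fold higher number from compound 2 to compound 3 (1.06 log units; beyond the scatter) as the first single-place step, so the outer end of the propyl ester chain of compound 2 is a place where one atom can move the number by a large margin. The step comes with little change in the counted features: the heavy-atom count stays the same, no ring is involved and no net charge appears, while a hydrogen-bond donor and a hydrogen-bond acceptor enter with the hydroxy. No measurement bearing on the reason for this loss is available, so the step stands as an observation only.

The compounds shown leave open whether the loss belongs to hydroxy itself or would also follow a methoxy or an amine on the same carbon, and whether a longer chain such as butyl would keep the number of compound 2. Also open, on these data alone, is whether the step would keep its size with the rest of compound 1 in place.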